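The source may report more compounds than this note shows. Statements on the series, on what has been measured and on what is new or still open speak of the compounds shown alone.

Measured compounds in an ADME assay on Vero cells (Chlorocebus sabaeus) for cytotoxicity, read by MTT assay, with a stated time of 48 h; a lower number here means a stronger inhibitor, a higher number a weaker inhibitor:
compound 1 `O=C(OC1CCC(CN2CCN(c3cc(=O)c4cc(C(F)(F)F)cc([N+](=O)[O-])c4s3)CC2)CC1)c1cccc(C(F)(F)F)c1` — > 64 ug/mL
compound 2 `CC(=O)OC1CCC(CN2CCN(c3cc(=O)c4cc(C(F)(F)F)cc([N+](=O)[O-])c4s3)CC2)CC1` — > 64 ug/mL
compound 3 `O=C(OC1CCC(CN2CCN(c3cc(=O)c4cc(C(F)(F)F)cc([N+](=O)[O-])c4s3)CC2)CC1)c1ccco1` — > 64 ug/mL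

In this assay compound 1 gives only a limit, > 64 ug/mL, not a number. Compound 2 likewise returns a limit, > 64 ug/mL. Compound 3 also stops at a limit, > 64 ug/mL. All three ester variants of the shared core thus sit at the limit of > 64 ug/mL in this assay, at which 3 of the 3 values shown sit, so no ranking among them is possible, and the steps between them cannot be read: a step that the two limits leave unreadable from compound 1 to compound 2, a step that the two limits leave unreadable from compound 1 to compound 3, and a step that the two limits leave unreadable from compound 2 to compound 3. For the measured compounds named here, what the measured set shows is only that exchanging the group on the carbonyl carbon among methyl, furan-2-yl and 3-(trifluoromethyl)phenyl never brought the value inside the measurable window.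

Compound 4 `COc1ccc(C(=O)OC2CCC(CN3CCN(c4cc(=O)c5cc(C(F)(F)F)cc([N+](=O)[O-])c5s4)CC3)CC2)cc1` is the next ester of the same core. Its change from compound 1 is 4-methoxyphenyl in place of 3-(trifluoromethyl)phenyl on a carbonyl carbon. The measured steps that touch the same carbonyl carbon are all unreadable, so no size can be assigned to the expected step; the data give no sign of any ester variant becoming measurable.

Compound 4 is therefore expected to return a limit as well, with an estimated step that the limit leaves unreadable from compound 1 to compound 4 that is not expected to be readable. The estimate for compound 4 in this assay is 90 ug/mL, within 45 ug/mL to 180 ug/mL.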

Compound 4, half-maximal inhibitory concentration: > 64 ug/mL
Compound 4 was reported as a limit (the forecaster's own chance of this, stated with the estimate: 85%); the middle value does not contradict the limit.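

In this assay compound 4 gives > 64 ug/mL, which is a limit and not a number. No new step can be read between compound 4 and compound 1, compound 2 or compound 3: the limit of > 64 ug/mL in this assay, at which 4 of the 4 values shown sit.

The compounds shown leave open how far each ester lies from that limit, and whether any group on the carbonyl carbon gives a measurable value.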